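A few compounds are considered here, and "the series" means these few. Any claim that something is new, unique, unknown or untested is made for them only; others in the source may bear on it.

Four compounds share one core and differ only in the group on a saturated chain carbon bound to an aromatic nitrogen. Compound 1 `COc1cc(Cn2cc(CNC(=O)c3cn(-c4ccccc4)nc3-c3ccccc3)nn2)cc(OC)c1` gives 2400 nM in a functional assay on MCF7 cells (Homo sapiens) for antiproliferative activity, read by sulforhodamine B assay, with a stated time of 48 h; on this read-out lower numbers stand for stronger inhibition of growth and higher numbers for weaker inhibition of growth. Compound 2 `O=C(NCc1cn(Cc2ccc(F)cc2)nn1)c1cn(-c2ccccc2)nc1-c1ccc(Cl)cc1` gives 570 nM in this assay. Compound 3 `COc1ccc(Cn2cc(CNC(=O)c3cn(-c4ccccc4)nc3-c3ccc(Cl)cc3)nn2)cc1OC` reaches only the limit > 100000 nM in this assay, so its number is not known. That value sits at the limit of > 100000 nM in this assay, at which 1 of the 3 values shown sits. For the measured compounds named here, the one measured step at this position, an at least 170-fold higher number from compound 2 to compound 3 (2.24 log units; beyond the scatter), is large. Compound 4 `COc1cc(Cn2cc(CNC(=O)c3cn(-c4ccccc4)nc3-c3ccc(Cl)cc3)nn2)cc(OC)c1` differs from compound 3 by 3,5-dimethoxyphenyl in place of 3,4-dimethoxyphenyl on a saturated chain carbon bound to an aromatic nitrogen. Compound 1 carries the same 3,5-dimethoxyphenyl and gives a measured 2400 nM. Compound 4 is therefore expected to fall well below the limit, an at least 33-fold lower number from compound 3 to compound 4 (1.52 log units; beyond the scatter). Compound 4 is estimated at 3000 nM, between 700 nM and 30000 nM.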

Compound 4, concentration for 50% growth inhibition: 150 nM
Compound 4: the middle estimate sits 20-fold (1.30 log units) above what was measured, and the stated range ends above it.
By their numbers in this assay, from the lowest: compound 4; then compound 2; then compound 1. At a limit, above all of these: compound 3.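

Compound 3 remains a limit rather than a number: the limit of > 100000 nM in this assay, at which 1 of the 4 values shown sits. The arrangement of the two methoxy groups on this ring therefore matters greatly, since 3,5-dimethoxyphenyl in place of 3,4-dimethoxyphenyl gives an at least 660-fold lower number from compound 3 to compound 4 (2.82 log units; beyond the scatter). This 3,5-dimethoxyphenyl group also outperforms 4-fluorophenyl, with a 3.8-fold lower number from compound 2 to compound 4 (0.58 log units; beyond the scatter), and chloro in place of hydrogen on an aromatic carbon adds a 16-fold lower number from compound 1 to compound 4 (1.20 log units; beyond the scatter).

Still open, going by these compounds, is how an unsubstituted phenyl or a 3,4,5-trimethoxyphenyl would behave on this saturated chain carbon. Also open, on these data alone, is whether the chloro step holds with groups other than 3,5-dimethoxyphenyl.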